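The compounds below may be only part of what the source reports. "The series", "measured", "known", "first", "only" and "open" are said of these compounds alone.

Of the compounds shown here, three of one series have been measured in an assay on cells for antagonist activity at transient receptor potential cation channel subfamily V member 4 (Homo sapiens), read by FLIPR and calcium flux, with a stated time of 10 min; a higher number here means a weaker inhibitor, a lower number a stronger inhibitor. Compound 1 `N#Cc1ccc(O[C@H]2CN(S(=O)(=O)c3ccc(Cl)cc3Cl)C[C@H]2CO)cc1F` gives 50 nM in this assay. Compound 2 `N#Cc1ccc(O[C@H]2CN(S(=O)(=O)c3ccc(Cl)cc3Cl)C[C@]2(O)CO)cc1F`, which carries a hydroxy in place of a hydrogen on a saturated ring carbon, gives 100 nM; the step of a 2.0-fold higher number from compound 1 to compound 2 (0.30 log units; within the scatter) stays within the scatter. Compound 3 `N#Cc1ccc(O[C@H]2CN(S(=O)(=O)c3ccc(Cl)cc3Cl)C[C@@H]2CO)cc1F` gives 200 nM; the step of a 4.0-fold higher number from compound 1 to compound 3 (0.60 log units; beyond the scatter) is modest, and the fact that compounds 1 and 3 differ only in the configuration as drawn is the only thing that separates these two. Compound 3 therefore stands highest of the three numbers, with compound 2 nearest and compound 1 furthest.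

Compound 4 `N#Cc1ccc(O[C@H]2CN(S(=O)(=O)c3ccc(Cl)cc3Cl)C[C@@H]2O)cc1F` has not yet been measured. It differs from compound 3 in one place: hydroxy in place of hydroxymethyl on a saturated ring carbon. Within the data shown here, no measured step trims a hydroxymethyl to a hydroxy, so neither measured step bears directly on this change. The nearest guide is the addition of a hydroxy on a saturated ring carbon in the step of a 2.0-fold higher number from compound 1 to compound 2 (0.30 log units; within the scatter), which stayed within the scatter, while the change of configuration in the step of a 4.0-fold higher number from compound 1 to compound 3 (0.60 log units; beyond the scatter) was modest. A change of this kind is therefore expected to move the number little, in either direction, and most likely not beyond the scatter. In this assay compound 4 is expected to give about 300 nM, between 100 nM and 900 nM, which means an expected step of a 1.5-fold higher number from compound 3 to compound 4 (0.18 log units; within the scatter).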

Compound 4, half-maximal inhibitory concentration: 40 nM
For compound 4 the middle estimate is 7.5-fold (0.88 log units) above the measured one; the measured number lies below the stated range.
By their numbers in this assay, from the lowest: compounds 4, 1, 2 and 3 (each within the scatter of the next, the first and the last beyond it).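

In this assay, among these compounds, the hydroxymethyl on this saturated ring carbon proves dispensable, since trimming it to a hydroxy gives (a 5.0-fold lower number from compound 3 to compound 4 (0.70 log units; beyond the scatter)), a step in the stronger direction that the earlier compounds, all of which kept the hydroxymethyl, could not reveal. The same direction appears when the hydroxymethyl leaves the carbon that already bears the hydroxy in compound 2, with hydrogen in its place (a 2.5-fold lower number from compound 2 to compound 4 (0.40 log units; beyond the scatter)), so both steps that remove this group lower the number. The compounds shown offer nothing that explains either step.

From the compounds shown here alone, it remains open whether the hydroxy of compound 4 would keep its number in the opposite configuration at this carbon, as configuration at this position mattered for the hydroxymethyl pair. Also open, going by these compounds, is how an amine, a methoxy or a longer chain such as hydroxyethyl would behave on the same ring carbon, and so whether the hydroxy itself matters there or only the absence of the hydroxymethyl.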